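Methyl for chloro on the benzyl ring: expected limit

The source may hold more compounds than are shown below. What is called first, only, known or untested is meant among the compounds shown, and "the series" means these compounds.

Of the compounds shown here, three have been measured in a functional assay on NIH3T3 cells (Mus musculus); a higher number here means that more compound is needed for the effect, a lower number that less compound is needed.
Compound 1 `CSCC[C@H](NC(=O)c1ccc(NCc2cncn2Cc2cccc(C#N)c2)cc1-c1ccccc1)C(=O)O` gives the limit > 10 uM.
Compound 2 `CSCC[C@H](NC(=O)c1ccc(NCc2cncn2Cc2ccc(C#N)cc2)cc1-c1ccccc1)C(=O)O` gives the limit > 10 uM.
Compound 3 `CSCC[C@H](NC(=O)c1ccc(NCc2cncn2Cc2ccc(Cl)cc2)cc1-c1ccccc1)C(=O)O` gives the limit > 10 uM.

All three values are limits of this assay, not numbers: the limit of > 10 uM in this assay, at which 3 of the 3 values shown sit. For the measured compounds named here, compound 3 thus stands at that limit, and no step between it and the others can be read. The steps a step that the two limits leave unreadable from compound 1 to compound 3, a step that the two limits leave unreadable from compound 2 to compound 3 and a step that the two limits leave unreadable from compound 1 to compound 2 all remain unreadable in size.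

Compound 4 `CSCC[C@H](NC(=O)c1ccc(NCc2cncn2Cc2ccc(C)cc2)cc1-c1ccccc1)C(=O)O` is not yet measured. It differs from compound 3 in one place: methyl in place of chloro on an aromatic carbon. Going by the values given here, the measured step that bears on this change is the one from compound 2 to compound 3, chloro in place of cyano on an aromatic carbon, and it too is unreadable, since both of its ends sit at the limit. Among the compounds with values here, no measured step therefore gives a size or a direction to expect in this assay for the change to compound 4. The three compounds only show that cyano in either place or chloro on this ring leaves the effect beyond the limit.

Compound 4 is expected most likely to be reported as a limit as well. As a number, compound 4 is estimated near 20 uM with a range from 8 uM to 100 uM. The step this estimate means, a step that the limit leaves unreadable from compound 3 to compound 4, is expected to be small.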

Compound 4, concentration for half-maximal effect: > 10 uM
Compound 4 gave a limit, no number; the forecaster's own chance of this, stated with the estimate: 85%; the middle value is on the limit's open side.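

In this assay compound 4 gives > 10 uM, which is a limit and not a number. Its steps to compound 1, compound 2 and compound 3 therefore cannot be read, and the whole set stands alike: the limit of > 10 uM in this assay, at which 4 of the 4 values shown sit.

The compounds shown leave open whether any group on this benzyl ring brings the effect to a readable number, and how the four compounds would rank.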